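From methoxy to chloro on the aromatic ring

The source may report more compounds than this note shows. Statements on the series, on what has been measured and on what is new or still open speak of the compounds shown alone.

Compound 1 `O=S1(=O)C=C(Sc2nnc(C3CCCCC3)o2)c2ccccc21` gives 3000 nM
Compound 2 `COc1ccccc1-c1nnc(SC2=CS(=O)(=O)c3ccccc32)o1` gives 3000 nM

In an ADME assay on HEK293 cells (Homo sapiens) for cytotoxicity, read by fluorescence and resazurin assay, with a stated time of 24 h (a lower number here means that less compound is tolerated, a higher number that more compound is tolerated), compound 2 gives 3000 nM and stands level with its nearest neighbour, compound 1 at 3000 nM on the same scale. Compound 3 `O=S1(=O)C=C(Sc2nnc(-c3ccccc3Cl)o2)c2ccccc21` keeps the shared core and carries chloro in place of methoxy on an aromatic carbon, ortho to a large group (chloro in place of methoxy on an aromatic carbon), so that 2-methoxyphenyl becomes 2-chlorophenyl.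

Within the data shown here, only one measured step bears on this change: no change at the digits printed from compound 1 to compound 2 (within the scatter), where 2-methoxyphenyl stands in place of cyclohexyl. That exchange replaces a whole group, whereas the one considered here alters a single substituent on it. Among the measured compounds shown here, no measured pair compares chloro with methoxy directly, so the evidence is thin, and one step cannot rule out a larger shift. Even so, no shift beyond the scatter is expected in this assay, and neither direction is favoured. The estimated step is no change at the digits printed from compound 2 to compound 3 (within the scatter) and it stays within the scatter. Compound 3 is expected at 3000 nM, with an estimated range from 1300 nM to 7000 nM as the measurement is awaited.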

Compound 3, half-maximal cytotoxic concentration: 4000 nM
Estimate against measurement, compound 3: 1.3-fold (0.12 log units) below, within the range that was stated.
By their numbers in this assay, from the lowest: compounds 1, 2 and 3 (each within the scatter of the next).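

In this assay the exchange of methoxy for chloro on an aromatic carbon, ortho to a large group, gives a 1.3-fold higher number from compound 2 to compound 3 (0.12 log units; within the scatter) and so reads a single substituent directly, where the earlier pair had compared only whole groups. Together with a 1.3-fold higher number from compound 1 to compound 3 (0.12 log units; within the scatter) on the exchange of cyclohexyl for 2-chlorophenyl, it shows that cyclohexyl, 2-methoxyphenyl and 2-chlorophenyl on the shared core all lie within the scatter of one another in this assay and that, across these three compounds, neither the whole group nor this one substituent on it separates the values. Nothing available here bears on why these values lie together.

The compounds shown leave open whether a quite different substituent at this place on the aromatic ring, such as an amine or a carboxylic acid, would still stay within the scatter, and whether chloro on another carbon of that ring would read the same. They also leave open whether a longer chain in place of the ring would keep the value level with these three compounds.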